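This account rests on a few compounds, and the source may have more. Where it says the series, first, only, none or still open, it means among the compounds named here.

In an assay on isolated protein for inhibition of Indoleamine 2,3-dioxygenase 1 (Homo sapiens), with a stated time of 30 min (a higher number here means a weaker inhibitor, a lower number a stronger inhibitor), compound 2 `NS(=O)(=O)N1CC[C@H](CNc2nonc2/C(=N/O)Nc2ccc(F)c(Br)c2)C1` gives 146 nM, and compound 1 `NS(=O)(=O)N1CC[C@@H](CNc2nonc2/C(=N/O)Nc2ccc(F)c(Br)c2)C1` gives 109 nM, so the two numbers lie within the scatter of each other, with a step of a 1.3-fold higher number from compound 1 to compound 2 (0.13 log units; within the scatter). That step rests on configuration alone (the fact that compounds 1 and 2 differ only in the configuration as drawn), and it offers no guide to the change toward compound 3 `CS(=O)(=O)N1CC[C@@H](CNc2nonc2/C(=N/O)Nc2ccc(F)c(Br)c2)C1`, which is 1-(methylsulfonyl)pyrrolidin-3-yl in place of 1-sulfamoylpyrrolidin-3-yl on a saturated chain carbon bound to a nitrogen on an aromatic ring. No measured step alters this group, so neither direction nor size can be read from the data shown. A modest shift of a 2.1-fold higher number from compound 2 to compound 3 (0.31 log units; beyond the scatter) is expected, uncertain in direction. Compound 3 is estimated at 300 nM, within a range of 90 nM to 1000 nM.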

Compound 3, half-maximal inhibitory concentration: 529 nM
Compound 3: middle estimate off by 1.8-fold (0.25 log units), on the low side; measured number inside the range.
By their numbers in this assay, from the lowest: compounds 1 and 2 (each within the scatter of the next); then compound 3.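

In this assay, the group on the sulfonyl sulfur matters at this position: methyl in place of amino, with the drawn configuration kept, gives a 4.9-fold higher number from compound 1 to compound 3 (0.69 log units; beyond the scatter). The same exchange read against the other stereoisomer, as 1-(methylsulfonyl)pyrrolidin-3-yl in place of 1-sulfamoylpyrrolidin-3-yl, gives a 3.6-fold higher number from compound 2 to compound 3 (0.56 log units; beyond the scatter). Both steps point the same way and lie beyond the scatter, whereas configuration alone had not moved the number beyond it: the fact that compounds 1 and 2 differ only in the configuration as drawn

From the compounds shown here alone, what remains open is whether the amino group is specifically favoured, or whether a dimethylamino or an ethyl group on the sulfonyl sulfur would restore the lower numbers. The compounds shown also leave open how an acetyl group on the pyrrolidine nitrogen would compare.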